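Swapping methylsulfanyl for methylsulfonyl in compound 2

This account rests on a few compounds, and the source may have more. Where it says the series, first, only, none or still open, it means among the compounds named here.

Measured in a functional assay on the whole organism for antagonist activity, with Mus musculus as the target; on this read-out lower numbers stand for an effect already at smaller amounts and higher numbers for an effect only at larger amounts of compound:
Compound 1 `CCSc1nnc(-c2ccccc2)n1C`: > 200 mg/kg (a limit)
Compound 2 `CSc1nc(-c2ccccc2)n(C)n1`: > 100 mg/kg (a limit)

Neither measured compound has a true number yet, which leaves little to work from. Compound 2, the starting point here, is reported only as a limit of > 100 mg/kg. Among the measured compounds shown here, compound 1 is also reported only as a limit, and no measured pair shows how far a single structural change can move the dose.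

Compound 3 `Cn1nc(S(C)(=O)=O)nc1-c1ccccc1` is still to be measured. It carries methylsulfonyl in place of methylsulfanyl on an aromatic carbon, and the rest of compound 2 stays as it is. For the measured compounds named here, with no measured step to lean on, this is a cautious guess. A modest move toward smaller doses is expected, and compound 3 could easily turn out to be a limit as well. The estimated step is an at least 1.2-fold lower number from compound 2 to compound 3 (0.09 log units; that floor lies within the scatter). In this assay the expected value for compound 3 is 80 mg/kg, with an estimated range from 20 mg/kg to 250 mg/kg.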

Compound 3, dose for half-maximal effect: > 200 mg/kg
Compound 3 gave a limit, no number; the forecaster's own chance of this, stated with the estimate: 50%; middle value at least 2.5-fold (0.39 log units) from the limit.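

Among the compounds shown here, compound 2 and compound 3 are both reported only as limits in this assay, so no step between them can be read. The compounds shown leave open the true dose for half-maximal effect of each compound, and whether methylsulfonyl in place of methylsulfanyl on an aromatic carbon changes that dose at all.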